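Swapping Methoxy for Amino on the Aryl Tail

A few compounds are considered here, and "the series" means these few. Any claim that something is new, unique, unknown or untested is made for them only; others in the source may bear on it.

Two compounds have been measured in an assay for inhibition of Fatty-acid amide hydrolase 1 (Rattus norvegicus); a lower number here means a stronger inhibitor, a higher number a weaker inhibitor:
compound 1 `O=C(CCCCCCc1cccc(Cl)c1Cl)c1ncc(-c2ccccn2)o1` gives 0.9 nM
compound 2 `COc1ccc(CCCCCCC(=O)c2ncc(-c3ccccn3)o2)cc1` gives 6.2 nM

Within the data shown here, compound 2 has the higher of the two numbers, so it is the weaker inhibitor of the pair; the only measured step, a 6.9-fold higher number from compound 1 to compound 2 (0.84 log units; beyond the scatter), sets it apart from compound 1 by more than the scatter. Compound 3 `Nc1ccc(CCCCCCC(=O)c2ncc(-c3ccccn3)o2)cc1` keeps everything of compound 2 except that (amino in place of methoxy on an aromatic carbon). Among the measured compounds shown here, no measured step covers a change of this kind: the one step available, a 6.9-fold higher number from compound 1 to compound 2 (0.84 log units; beyond the scatter), exchanges the whole aromatic group at the end of the chain rather than a single substituent on it, so it says little about what an amino in place of a methoxy does. With nothing to argue for a shift in either direction, the expectation for compound 3 is a number close to that of compound 2, with a step of a 1.3-fold higher number from compound 2 to compound 3 (0.11 log units; within the scatter) that is expected to stay within the scatter. Compound 3 is therefore estimated at 8 nM, expected to fall between 3 nM and 25 nM.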

Compound 3, inhibition constant: 3 nM
Beside the measured number, compound 3's estimate is 2.7-fold (0.43 log units) above it; the range from low to high includes it.
By their numbers in this assay, from the lowest: compound 1; then compound 3; then compound 2.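

In this assay, the step of a 2.1-fold lower number from compound 2 to compound 3 (0.32 log units; beyond the scatter) shows that exchanging one small substituent on the aromatic carbon para to a large group, amino in place of methoxy, is enough to move the number by a modest amount beyond the scatter, which the earlier whole-group exchange could not reveal. Even so, the new amino compound does not close the gap to the dichlorinated tail, as a 3.3-fold higher number from compound 1 to compound 3 (0.52 log units; beyond the scatter) is also beyond the scatter, so compound 1 keeps the lowest number of the three. The swap brings in a hydrogen-bond donor where the methoxy had none, but no measurement here bears on why the number moved, so that difference remains a description and not an explanation.

On these data alone, what remains open is whether the gain belongs to amino specifically: a hydroxyl, a dimethylamino or an acetamide group at the same place would help separate these possibilities. It is also unclear how an amino group would behave on the dichlorinated tail of compound 1, or with a shorter or longer chain.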